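Swapping the Urea for a Chlorobenzyl Group on a Weak Acid

The compounds below may be only part of what the source reports. "The series", "measured", "known", "first", "only" and "open" are said of these compounds alone.

Compound 1 `CNC(=O)c1cnc(NC(=O)NC2CCCCC2)n2nc(-c3ccco3)nc12`: 18700 nM
Compound 2 `O=C(Nc1ncc(C(=O)O)c2nc(-c3ccco3)nn12)NC1CCCCC1`: 59400 nM
Compound 3 `CCOC(=O)c1cnc(NC2CCCCC2)n2nc(-c3ccco3)nc12`: 131 nM

All three compounds share one core and were tested in an assay on CHO cells for displacement of a labelled ligand from adenosine receptor A3 (Homo sapiens); on this read-out lower numbers stand for stronger inhibition and higher numbers for weaker inhibition. Compound 2 stands at the highest number of the three, meaning the weakest binding; compound 1 lies nearest to it and compound 3 furthest away. Among the measured compounds shown here, the one measured single-point step is a 3.2-fold higher number from compound 1 to compound 2 (0.50 log units; beyond the scatter), a change at the carbonyl carbon rather than on the ring nitrogen.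

Compound 4 `O=C(O)c1cnc(NCc2ccc(Cl)cc2)n2nc(-c3ccco3)nc12` differs from compound 2 in this way: 4-chlorobenzyl in place of cyclohexylcarbamoyl on a nitrogen on an aromatic ring. For the measured compounds named here, no measured step touches the group on that ring nitrogen, so the direction of the change cannot be read from the data. Compound 3 carries a different group on the same nitrogen and a much lower number, but it also differs at the carbonyl carbon, so its value cannot be assigned to either change alone. Compound 4 is therefore expected to remain a weak binder, with a number estimated at 20000 nM, between 3000 nM and 100000 nM. The expected step is a 3.0-fold lower number from compound 2 to compound 4 (0.47 log units; beyond the scatter).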

Compound 4, inhibition constant: 11600 nM
Estimate against measurement, compound 4: 1.7-fold (0.24 log units) above; measured number inside the range.
By their numbers in this assay, from the lowest: compound 3; then compounds 4 and 1 (each within the scatter of the next); then compound 2.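

Replacing cyclohexylcarbamoyl with 4-chlorobenzyl on a nitrogen on an aromatic ring gives, in this assay, a 5.1-fold lower number from compound 2 to compound 4 (0.71 log units; beyond the scatter), so the group at this position affects binding. Compound 2 and compound 4 share the hydroxy on the carbonyl carbon, so this step isolates the nitrogen change, which the two-place difference involving compound 3 could not do. Still, the step is modest, and compound 4 remains a weak binder at 11600 nM, while nothing available explains why the number falls.

This single swap removes the carbonyl and exchanges the non-aromatic ring for a chlorinated aromatic one, so the contribution of each part stays unresolved. Going by these compounds, an unsubstituted benzyl group on that nitrogen would help separate the effect of the chlorine from that of the ring, and it remains open whether the gain would carry over to compounds with a methylamino group on the carbonyl carbon.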